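This account rests on a few compounds, and the source may have more. Where it says the series, first, only, none or still open, it means among the compounds named here.

Working notes on the series.

Compound 1 `Nc1c(Br)cc(Br)cc1/C=C(\C(=O)c1ccc(Br)cc1)S(=O)(=O)c1ccc(Br)cc1` is one of three measured compounds. In a functional assay on DU-145 cells (Homo sapiens) for inhibition, read by trypan blue exclusion, with a stated time of 96 h (on this read-out lower numbers stand for stronger inhibition of growth and higher numbers for weaker inhibition of growth), compound 1 gives 25000 nM, the highest of the three numbers, so on this read-out it is the weakest inhibitor of growth among them. Compound 2 `O=C(/C(=C\c1cccc(Cl)c1Cl)SCc1ccc(Cl)cc1)c1ccc(Cl)cc1`, which carries a thioether in place of the sulfone and a different substitution on the shared core, gives 10000 nM in this assay; its number is nearest to that of compound 1 and the gap lies beyond the scatter. Compound 3 `CSc1ccc(/C=C(\C(=O)c2ccc(Br)cc2)S(=O)(=O)c2ccc(C)cc2)cc1` gives 1000 nM in this assay, the lowest number of the set and furthest from compound 1, again beyond the scatter. Within the data shown here, no step between two measured compounds differing in a single place is available here.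

Compound 4 `O=C(/C(=C\c1ccc(F)cc1)S(=O)(=O)c1ccc(Br)cc1)c1ccc(Br)cc1` has not yet been measured. It differs from compound 1 by 4-fluorophenyl in place of 2-amino-3,5-dibromophenyl on a double-bonded chain carbon bound to a double-bonded chain carbon. Compound 3, which also carries a plain substituted phenyl on that chain carbon, shows a much lower number than compound 1, which suggests that removing the amino-dibromo pattern is compatible with stronger inhibition. The step from compound 1 to compound 4 is expected to be toward a lower number, beyond the scatter, estimated at an 8.3-fold lower number from compound 1 to compound 4 (0.92 log units; beyond the scatter). Compound 4 is thus expected to give about 3000 nM in this assay, within a range of 800 nM to 12000 nM.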

Compound 4, concentration for 50% growth inhibition: 4000 nM
Compound 4: the middle estimate sits 1.3-fold (0.12 log units) below what was measured, within the range that was stated.
By their numbers in this assay, from the lowest: compound 3; then compound 4; then compound 2; then compound 1.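

This gives the series its first comparison across a single place: in this assay the change to 4-fluorophenyl from 2-amino-3,5-dibromophenyl on a double-bonded chain carbon bound to a double-bonded chain carbon gives a 6.3-fold lower number from compound 1 to compound 4 (0.80 log units; beyond the scatter) and so shows that the group at this position alone moves the number, with the rest of the structure held fixed. It also shows that stronger inhibition of growth at this position does not depend on the amino group or the two bromines, since the entering group carries neither. No supporting measurement bears on why the number moves with this change.

From the compounds shown here alone, the step replaces the amino group and both bromines and adds a fluorine at once, so it remains open which of these changes carries the shift. A plain phenyl, a 2-aminophenyl without bromine or a 4-methoxyphenyl on this chain carbon would help to separate these contributions, and the shown compounds leave open how the number responds to any of them.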